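The compounds below may be only part of what the source reports. "The series", "measured", "known", "first", "only" and "open" are said of these compounds alone.

Measured so far:
- compound 1, `COc1cc(/C=C/C2CC(=O)C=CO2)cc(OC)c1OC`: 149 uM
- compound 2, `COc1ccc(/C=C/C2CC=CC(=O)N2)cc1`: > 1090 uM
- compound 3, `COc1ccc(/C=C/C2CC=CC(=O)N2)cc1OC`: > 964 uM

In a functional assay on MCF7 cells (Homo sapiens) for inhibition, read by sulforhodamine B assay, with a stated time of 48 h (a lower number here means a stronger inhibitor of growth, a higher number a weaker inhibitor of growth), compound 1 gives 149 uM. Compound 2 reaches only a limit of the assay, > 1090 uM. Compound 3 likewise reaches only a limit of the assay, > 964 uM, so its standing is known only as a limit, and one further value shown is also a limit. The step that the two limits leave unreadable from compound 2 to compound 3 is therefore not readable in size, both of its ends sitting at limits, the limit of > 1090 uM in this assay, at which 1 of the 3 values shown sits, and (the limit of > 964 uM in this assay, at which 1 of the 3 values shown sits).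

Compound 4, `COc1cc(/C=C/C2CC=CC(=O)N2)cc(OC)c1OC`, differs from compound 3 by methoxy in place of hydrogen on an aromatic carbon. Going by the values given here, the only measured step that bears on it is a step that the two limits leave unreadable from compound 2 to compound 3, which added a methoxy in place of hydrogen on an aromatic carbon and gave no readable size. Among the compounds with values here, compound 1, which carries the same three methoxy groups on a different core, gives 149 uM, but no step to compound 1 is available here. No step beyond the scatter is therefore expected in this assay, and a further limit is the most likely outcome. The step that the limit leaves unreadable from compound 3 to compound 4 is expected to stay within the scatter. Compound 4 is estimated at 1000 uM, within a range from 300 uM to 3000 uM.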

Compound 4, concentration for growth inhibition (reported as GI): > 864 uM
Compound 4: only a limit was reported; the forecaster's own chance of this, stated with the estimate: 60%; the middle value is on the limit's open side.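

Like compound 3, compound 4 reaches only a limit in this assay, > 864 uM. The steps that add a methoxy in place of hydrogen on an aromatic carbon cannot be read, so this position, ortho to a methoxy group and meta to a methoxy group, gains no measurable size of effect on this core, and the third methoxy group gives no readable growth inhibition. Going by these compounds alone, what is new is the pair with the same three methoxy groups on both sides, where the change is confined to the six-membered non-aromatic ring and the number rises by an at least 5.7-fold higher number from compound 1 to compound 4 (0.76 log units; beyond the scatter), making the core exchange the only readable change so far.

With compounds 2, 3 and 4 all at limits, any effect of the methoxy groups on this core remains unresolved, and their contribution on the core of compound 1 is equally unknown. Also open, going by these compounds, is what a hydroxy group or an amine at this aromatic carbon would do on either core.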